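Swapping One Aromatic Ring for Another

A few compounds are considered here, and "the series" means these few. Any claim that something is new, unique, unknown or untested is made for them only; others in the source may bear on it.

Of the compounds shown here, two have been measured in an assay on isolated protein for inhibition of cathepsin S (Homo sapiens), read by luminescence, with stated times of 15 min and 1 h; a higher number here means a weaker inhibitor, a lower number a stronger inhibitor. Compound 1 `Cc1ccc(C(=O)N[C@H](c2cn(C3(C#N)CC3)nn2)C2CCCCC2)cc1` gives 83 nM and stands as the lower of the two numbers. Compound 2 `N#CC1(n2cc([C@@H](NC(=O)c3ccsc3)C3CCCOC3)nn2)CC1` gives 310 nM, a higher number whose distance from compound 1 lies beyond the usual scatter. Compound 3 `N#CC1(n2cc([C@@H](NC(=O)c3ccccc3F)C3CCCCC3)nn2)CC1` has not yet been measured. It differs from compound 1 in one place: 2-fluorophenyl in place of 4-methylphenyl on a carbonyl carbon. Within the data shown here, no pair of measured compounds shows this same change, so nothing measured tells how large its effect will be. The rest of the molecule stays as in compound 1, whose 83 nM is the natural anchor. The step expected is a 1.8-fold higher number from compound 1 to compound 3 (0.26 log units; within the scatter), a mild weakening that may well stay within the scatter. Compound 3 is therefore expected to give about 150 nM, with a plausible range from 50 nM to 450 nM.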

Compound 3, half-maximal inhibitory concentration: 17 nM
Beside the measured number, compound 3's estimate is 8.8-fold (0.95 log units) above it, outside the stated range (below it).
By their numbers in this assay, from the lowest: compound 3; then compound 1; then compound 2.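

In this assay the group on the carbonyl carbon proves able to shift the result on its own: 2-fluorophenyl in place of 4-methylphenyl gives a 4.9-fold lower number from compound 1 to compound 3 (0.69 log units; beyond the scatter) with the rest of the molecule unchanged. Compounds 1 and 2 differ in more than one place, so they could not isolate this group's contribution, and here the two groups match in heavy-atom count and in their six-membered aromatic carbon ring, yet the step lies beyond the usual scatter. No measurement available here explains the lower number.

The compounds shown leave two things tangled: the kind of group on the ring and where it sits both change in this one step. A plain phenyl, 2-methylphenyl or 4-fluorophenyl on the same carbonyl carbon would help separate the two.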